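The source may hold more compounds than are shown below. What is called first, only, known or untested is meant among the compounds shown, and "the series" means these compounds.

Working notes on the series. In an assay on MDA-MB-231 cells for displacement of a labelled ligand from C-X-C chemokine receptor type 4 (Homo sapiens), read by fluorescence and microscopy, with stated times of 10 min and 30 min (on this read-out higher numbers stand for an effect only at larger amounts of compound and lower numbers for an effect already at smaller amounts), compound 1 `Cc1ccccc1C(=O)NCc1ccc(CNS(=O)(=O)c2ccccc2C)cc1` gives 10 nM, the lowest of the two numbers in hand. Going by the values given here, compound 2 `Cc1ccccc1S(=O)(=O)NCc1ccc(CNC(=O)c2cccnc2)cc1` gives 1000 nM in this assay; the step of a 100-fold higher number from compound 1 to compound 2 (2.00 log units; beyond the scatter) is the only measured step, and it concerns the carbonyl side of the shared core. Compound 3 `Cc1ccccc1C(=O)NCc1ccc(CNS(=O)(=O)c2cccc(F)c2)cc1` is not yet measured. It differs from compound 1 by 3-fluorophenyl in place of 2-methylphenyl on a sulfonyl sulfur. Among the compounds with values here, no measured step touches the sulfonyl side, so the one measured step gives no direct guide; the pair of compound 1 and compound 2 shows only that a change on the carbonyl side gave a large step in this assay. A step toward a higher number beyond the scatter is possible, but its size cannot be read from these data; a modest change is expected, a 3.0-fold higher number from compound 1 to compound 3 (0.48 log units; beyond the scatter). For compound 3 the estimate in this assay is 30 nM, with a range of 5 nM to 300 nM.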

Compound 3, effective concentration (reported as EC, without a stated level of effect): 100 nM
Compound 3: middle estimate off by 3.3-fold (0.52 log units), on the low side; the measured number falls inside the stated range.
By their numbers in this assay, from the lowest: compound 1; then compound 3; then compound 2.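

In this assay, the sulfonyl side of the shared core also responds to change: 3-fluorophenyl in place of 2-methylphenyl on a sulfonyl sulfur gives a 10-fold higher number from compound 1 to compound 3 (1.00 log units; beyond the scatter), a modest step. Going by these compounds alone, this is the first measured step on this side, and the earlier pair spoke only to the carbonyl side. The two groups have the same heavy-atom count, one six-membered aromatic ring of carbon only and no hydrogen-bond donors or acceptors, so these counts do not separate them, and no measurement at hand accounts for the step.

The compounds shown leave open whether the step follows the loss of the methyl group or the entry of the fluorine, since the two change together. Also open, on these data alone, is how this position would respond to a plain phenyl or to an amine such as piperidine on the sulfonyl sulfur.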